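This account rests on a few compounds, and the source may have more. Where it says the series, first, only, none or still open, it means among the compounds named here.

In a functional assay on DU-145 cells (Homo sapiens) for cytotoxicity, read by MTT assay, with a stated time of 24 h (a higher number here means a weaker inhibitor, a lower number a stronger inhibitor), compound 2 `Cc1ccc(/C=C2\CN(Cc3cn(Cc4ccc(F)cc4)nn3)C/C(=C\c3ccc(C)cc3)C2=O)cc1` gives 49700 nM and compound 1 `O=C1/C(=C/c2ccccc2F)CN(C(=S)SCc2cn(Cc3ccccc3Cl)nn2)C/C1=C\c1ccccc1F` gives 46300 nM, two values within the scatter of each other. Compound 3 `O=C1/C(=C/c2ccccc2F)CN(C(=S)SCc2cn(Cc3ccccc3F)nn2)C/C1=C\c1ccccc1F` gives > 80000 nM, which is a limit of the assay. Compound 4 `Cc1ccc(/C=C2\CN(Cc3cn(Cc4cccc(Cl)c4)nn3)C/C(=C\c3ccc(C)cc3)C2=O)cc1` differs from compound 2 by 3-chlorophenyl in place of 4-fluorophenyl on a saturated chain carbon bound to an aromatic nitrogen. Among the measured compounds shown here, the one measured step bearing on this, fluoro in place of chloro on an aromatic carbon, is an at least 1.7-fold higher number from compound 1 to compound 3 (0.23 log units; that floor lies within the scatter), and it rests on (the limit of > 80000 nM in this assay, at which 1 of the 3 values shown sits). The core of compound 1 also differs from that of compound 2, so only a slightly lower number, if any, is expected in this assay. The expected step, a 1.2-fold lower number from compound 2 to compound 4 (0.09 log units; within the scatter), stays within the scatter. Compound 4 is estimated at 40000 nM, with an expected range of 18000 nM to 80000 nM.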

Compound 4, half-maximal inhibitory concentration: 33100 nM
Estimate against measurement, compound 4: 1.2-fold (0.08 log units) above; the measured number falls inside the stated range.
By their numbers in this assay, from the lowest: compounds 4, 1 and 2 (each within the scatter of the next). At a limit, above all of these: compound 3.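

In this assay, 3-chlorophenyl in place of 4-fluorophenyl on a saturated chain carbon bound to an aromatic nitrogen gives a 1.5-fold lower number from compound 2 to compound 4 (0.18 log units; within the scatter), so this change at this position cannot be told from the scatter on the shared core. Unlike the earlier halogen step, this step is read between two plain values, and that earlier step rests on a limit: the limit of > 80000 nM in this assay, at which 1 of the 4 values shown sits.

This step changes the halogen and its place together, and the compounds shown do not separate the two. On these data alone, how a benzyl group carrying an amine or a carboxylic acid would read in this assay stays open.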